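The compounds below may be only part of what the source reports. "The series", "measured", "known", "first", "only" and "open" are said of these compounds alone.

Measured in a functional assay on FM3A cells (Mus musculus) for antiproliferative activity; on this read-out higher numbers stand for weaker inhibition and lower numbers for stronger inhibition:
- Compound 1 `COc1cc(C(=O)c2sc(-c3ccc(-c4ccccc4)cc3)cc2N)cc(OC)c1OC`: > 10000 nM (a limit)
- Compound 2 `COc1ccc(-c2cc(N)c(C(=O)c3cc(OC)c(OC)c(OC)c3)s2)cc1OC`: 72 nM
- Compound 3 `COc1cc(C(=O)c2sc(-c3ccncc3)cc2N)cc(OC)c1OC`: 150 nM

Only two of these results are true numbers, and compound 3 has the higher of the two, which means weaker inhibition than compound 2. The result for compound 1 is a limit, so it gives no step size to work with.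

The next compound is compound 4 `COc1cc(C(=O)c2sc(-c3cccs3)cc2N)cc(OC)c1OC`, which keeps the shared core and changes one group on an aromatic carbon: thiophen-2-yl in place of pyridin-4-yl on an aromatic carbon. In words, thiophen-2-yl takes the place of pyridin-4-yl.

Within the data shown here, one measured step bears on this change, as it also swaps one aromatic group for another at the same place. That step is a 2.1-fold higher number from compound 2 to compound 3 (0.32 log units; beyond the scatter), which is modest in size. Among the measured compounds shown here, with only this single step as a guide, a large change in this assay would be a surprise, and the direction cannot be told with any confidence. The expected change is a 1.4-fold lower number from compound 3 to compound 4 (0.13 log units; within the scatter), so no clear shift beyond the scatter is anticipated. For compound 4 the estimated value is 110 nM, with an expected range from 35 nM to 400 nM.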

Compound 4, half-maximal inhibitory concentration: 1.7 nM
Compound 4: middle estimate off by 65-fold (1.81 log units), on the high side; the whole stated range lies above it.
By their numbers in this assay, from the lowest: compound 4; then compound 2; then compound 3. At a limit, above all of these: compound 1.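

Swapping one aromatic ring for another on the carbon next to the ring sulfur can shift the result far more than the earlier compounds suggested: the only earlier step between two true numbers in this assay was modest (a 2.1-fold higher number from compound 2 to compound 3 (0.32 log units; beyond the scatter)), whereas thiophen-2-yl in place of pyridin-4-yl gives a large change (an 88-fold lower number from compound 3 to compound 4 (1.95 log units; beyond the scatter)). The gain is not specific to replacing pyridin-4-yl, as thiophen-2-yl in place of 3,4-dimethoxyphenyl also gives a large change (a 42-fold lower number from compound 2 to compound 4 (1.63 log units; beyond the scatter)), so compound 4 has a lower number than either compound 2 or compound 3 by a margin beyond the scatter. Among these compounds, compound 1 stands at a limit, > 10000 nM, so no step to it can be read, and its place in the order is known only from that limit.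

The compounds shown do not separate the effect of the ring sulfur from that of the five-membered ring, a question that a furan-2-yl, thiophen-3-yl or plain phenyl group at this place would bear on. Nothing in the data shown accounts for the size of this jump.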